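The source may hold more compounds than are shown below. What is called first, only, known or untested is meant among the compounds shown, and "the series" means these compounds.

Values in a functional assay on KB cells (Homo sapiens) for inhibition; a higher number here means a weaker inhibitor, a lower number a stronger inhibitor:
- compound 1 `CCOC(=O)c1nc([C@@H]2O[C@H](CO)[C@@H](O)[C@H]2O)c(Cl)nc1Cl`: 20000 nM
- compound 2 `CCOC(=O)c1nc([C@@H]2O[C@H](CO)[C@@H](O)[C@H]2O)c(NC)nc1Cl`: > 100000 nM, a limit
- compound 3 `NC(=O)c1nc([C@@H]2O[C@H](CO)[C@@H](O)[C@H]2O)c(N)nc1Cl`: > 100000 nM, a limit

Compound 3 stands only at a limit, > 100000 nM. That is no isolated case: the limit of > 100000 nM in this assay, at which 2 of the 3 values shown sit.

Compound 4 `CCOc1nc(Cl)c(C(N)=O)nc1[C@@H]1O[C@H](CO)[C@@H](O)[C@H]1O` follows from compound 3 by ethoxy in place of amino on an aromatic carbon. Among the compounds with values here, one measured step bears on this, and only indirectly: an at least 5.0-fold higher number from compound 1 to compound 2 (0.69 log units; beyond the scatter), with methylamino in place of chloro on the same aromatic carbon. Within the data shown here, no measured step covers ethoxy, and compound 3 also differs from compound 1 at the carbamoyl group.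

Read in reverse, the step to compound 2 suggests that removing the amino group could lower the number in this assay, by a similar modest size. Because compound 1 reaches 20000 nM without an amino group, a measurable value for the new compound is plausible. Another limit for compound 4 remains a real possibility.

The expected step is an at least 2.0-fold lower number from compound 3 to compound 4 (0.30 log units; that floor lies within the scatter). The estimate for compound 4 is 50000 nM, with an expected range of 15000 nM to 100000 nM.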

Compound 4, half-maximal inhibitory concentration: > 100000 nM
Compound 4 ended at the assay's limit; the forecaster's own chance of this, stated with the estimate: 45%; middle value at least 2.0-fold (0.30 log units) away from the limit.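

In this assay compound 3 and compound 4 both stand only at limits, so the step between them cannot be read. The compounds shown leave open how ethoxy and amino compare on this aromatic carbon, with most of the series at one limit: the limit of > 100000 nM in this assay, at which 3 of the 4 values shown sit.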